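Dropping the acetoxy group from compound 1: what to expect

This account rests on a few compounds, and the source may have more. Where it says the series, first, only, none or still open, it means among the compounds named here.

Among the measured compounds shown here, compound 1 `CC(=O)Oc1ccccc1-c1nnc(CNc2c(C)n(C)n(-c3ccccc3)c2=O)o1` is one of two compounds measured in a physicochemical assay for lipophilicity, measured as octanol-water partition (on this read-out lower numbers stand for lower lipophilicity and higher numbers for higher lipophilicity), and in this assay compound 1 gives 1.98. That is the lower of the two numbers. For the measured compounds named here, its neighbour, compound 2 `Cc1ccccc1-c1nnc(CNc2c(C)n(C)n(-c3ccccc3)c2=O)o1`, gives 2.38 in this assay, and the step from one to the other, a number 0.40 log units higher from compound 1 to compound 2 (beyond the scatter), is the only measured step available, so it is the only guide to the present question.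

Compound 3 `Cc1c(NCc2nnc(-c3ccccc3)o2)c(=O)n(-c2ccccc2)n1C` has not been measured in this assay yet. It differs from compound 1 in a single place: hydrogen in place of acetoxy on an aromatic carbon. Seen one bond further out, the change reads 2-acetoxyphenyl to phenyl.

The measured step bears on this change only indirectly, since there methyl, not hydrogen, took the place of acetoxy. Removing the acetoxy group outright is expected to move the number in the same direction but by less, so the expected step of a number 0.22 log units higher from compound 1 to compound 3 (within the scatter) may well stay within the scatter. Compound 3 is therefore estimated at 2.2, somewhere between 1.75 and 2.65.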

Compound 3, partition coefficient: 2.02
Estimate against measurement, compound 3: 0.18 log units above, and the stated range covers the measured number.
By their numbers in this assay, from the lowest: compounds 1 and 3 (each within the scatter of the next); then compound 2.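

In this assay, hydrogen in place of acetoxy on the aromatic carbon gives a number 0.04 log units higher from compound 1 to compound 3 (within the scatter) and so, on this read-out, 2-acetoxyphenyl and phenyl cannot be told apart in this series. Methyl at the same place does stand apart, with a number 0.36 log units lower from compound 2 to compound 3 (beyond the scatter) on a step that lies beyond the usual spread of repeat measurements. The earlier pair alone could not show which group the gap went with, but across these three compounds the number separates only when methyl is present, while acetoxy and hydrogen sit together; nothing available explains why this is so.

What the compounds shown leave open is whether this holds for other groups on the same aromatic carbon, such as an ethyl chain, a primary amine or a carboxylic acid, and whether any of them would sit with methyl or with hydrogen and acetoxy. They also leave open whether the same three groups would keep this order on a different core, since all three comparisons share one core.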